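The compounds below may be only part of what the source reports. "The series", "measured", "known", "first", "only" and "open" are said of these compounds alone.

Measured so far in a functional assay on PC-3 cells (Homo sapiens) for cytotoxicity, read by MTT assay, with a stated time of 72 h; on this read-out higher numbers stand for weaker inhibition of growth and lower numbers for stronger inhibition of growth:

compound 1, `C[Se]/C(=N\C(=O)c1cnc2ccccc2c1)NC(=O)c1cnc2ccccc2c1`: 2330 nM
compound 2, `CS/C(=N\C(=O)c1cnc2ccccc2c1)NC(=O)c1cnc2ccccc2c1`: 76300 nM

For the measured compounds named here, compound 2 gives the higher of the two numbers in this assay, and the only measured step connecting it to another compound is a 33-fold higher number from compound 1 to compound 2 (1.52 log units; beyond the scatter), a large change that comes from the exchange of selenium for sulfur on the carbon with a double bond to nitrogen. Compound 3, `O=C(/N=C(/NC(=O)c1cnc2ccccc2c1)[Se]Cc1ccccc1)c1cnc2ccccc2c1`, is not yet measured. It differs from compound 2 in that (a group of 8 heavy atoms (7 carbon, 1 selenium; one six-membered aromatic ring of carbon only) in place of a group of 2 heavy atoms (1 carbon, 1 sulfur; no ring), on a carbon with a double bond to nitrogen). Going by the values given here, this change brings selenium back, so the one measured step bears on it directly and points toward a lower number; the benzyl part of the new group, however, has no counterpart among the measured compounds, so its contribution is unknown. Compound 3 is therefore expected to show a 25-fold lower number from compound 2 to compound 3 (1.41 log units; beyond the scatter). The estimate for compound 3 in this assay is 3000 nM, with a range from 800 nM to 12000 nM.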

Compound 3, concentration for 50% growth inhibition: 34800 nM
The estimate for compound 3 lay 12-fold (1.06 log units) below the measured number, outside the stated range (above it).
By their numbers in this assay, from the lowest: compound 1; then compound 3; then compound 2.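

In this assay, selenium on the carbon with a double bond to nitrogen does not alone secure the low number of compound 1: phenyl in place of hydrogen on the saturated chain carbon bound to the selenium atom gives a 15-fold higher number from compound 1 to compound 3 (1.17 log units; beyond the scatter) and so gives up most of that advantage. Set against the methylsulfanyl group, the larger selenium group gives only a 2.2-fold lower number from compound 2 to compound 3 (0.34 log units; beyond the scatter) and this modest step is still beyond the scatter. Thus the group carried on the selenium matters at this position as well as the selenium itself, and nothing shown here accounts for either step.

The compounds shown leave open how a benzyl group on sulfur would compare with compound 3 and with compound 2, which would separate the selenium exchange from the added phenyl. They also leave open whether an ethyl group on selenium, a shorter addition than benzyl, would retain the number of compound 1.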